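Dichlorobenzyl isomers: from compound 3 to compound 4

The source may report more compounds than this note shows. Statements on the series, on what has been measured and on what is new or still open speak of the compounds shown alone.

In a functional assay on CCRF-CEM cells (Homo sapiens) for antiproliferative activity, with a stated time of 72 h (a higher number here means a weaker inhibitor, a lower number a stronger inhibitor), compound 1 `OC[C@H]1O[C@@H](n2cnc3c(NCc4ccccc4F)ncnc32)[C@H](O)[C@@H]1O` gives 4600 nM and compound 3 `OC[C@H]1O[C@@H](n2cnc3c(NCc4ccc(Cl)cc4Cl)ncnc32)[C@H](O)[C@@H]1O` gives 86700 nM, the higher of the two numbers. Compound 2 `Cc1ccc(CNc2ncnc3c2ncn3[C@@H]2O[C@H](CO)[C@@H](O)[C@H]2O)cc1` reaches only a limit, > 166000 nM.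

Compound 4 `OC[C@H]1O[C@@H](n2cnc3c(NCc4ccc(Cl)c(Cl)c4)ncnc32)[C@H](O)[C@@H]1O` differs from compound 3 by 3,4-dichlorophenyl in place of 2,4-dichlorophenyl on a saturated chain carbon bound to a nitrogen on an aromatic ring. Two large steps bear on this change: a 19-fold higher number from compound 1 to compound 3 (1.28 log units; beyond the scatter) and an at least 36-fold higher number from compound 1 to compound 2 (1.55 log units; beyond the scatter). The floor of an at least 1.9-fold lower number from compound 2 to compound 3 (0.28 log units; that floor lies within the scatter) lies within the scatter. The 4-methylphenyl, 2,4-dichlorophenyl and 3,4-dichlorophenyl names all carry a 4 and 2-fluorophenyl does not, so no step beyond the scatter is expected in this assay. The expected change is a 1.1-fold lower number from compound 3 to compound 4 (0.03 log units; within the scatter). For compound 4, the estimated value is 80000 nM, with an expected range of 25000 nM to 200000 nM.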

Compound 4, half-maximal inhibitory concentration: 3800 nM
The estimate for compound 4 lay 21-fold (1.32 log units) above the measured number; measured number outside the range, below it.
By their numbers in this assay, from the lowest: compounds 4 and 1 (each within the scatter of the next); then compound 3. At a limit, above all of these: compound 2.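

In this assay, rearranging the same two chlorines carries a large step on its own: a 23-fold lower number from compound 3 to compound 4 (1.36 log units; beyond the scatter). The 3,4-dichlorophenyl group stands level with 2-fluorophenyl, a 1.2-fold lower number from compound 1 to compound 4 (0.08 log units; within the scatter), so neither two chlorines nor a 4 in the group name goes with a high number across these compounds, with compound 3 and compound 2 at the high end. The step of an at least 43-fold lower number from compound 2 to compound 4 (1.64 log units; beyond the scatter) is only a floor, set by the limit of compound 2: the limit of > 166000 nM in this assay, at which 1 of the 4 values shown sits.

What separates compound 3 from compound 4 in these cells cannot be told from these numbers. As far as these compounds go, whether 3-chlorophenyl, or a phenyl carrying an amine or a carboxylic acid, follows compound 4 or compound 3 stays open.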